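Homologation on the indole nitrogen in a 5-alpha-reductase series

The source may report more compounds than this note shows. Statements on the series, on what has been measured and on what is new or still open speak of the compounds shown alone.

Three compounds sharing one core were measured in an assay on Prostate gland for inhibition of steroid 5-alpha-reductase (Rattus norvegicus); on this read-out lower numbers stand for stronger inhibition and higher numbers for weaker inhibition. Compound 1 `CCCCn1ccc2cc(/C(C)=C/C(=O)Nc3ccccc3OCCCC(=O)O)ccc21` gives 43 nM. Compound 2 `CCCCCn1ccc2cc(/C(C)=C/C(=O)Nc3ccccc3OCCCC(=O)O)ccc21` gives 23 nM, and compound 3 `C/C(=C\C(=O)Nc1ccccc1OCCCC(=O)O)c1ccc2c(ccn2C(C)c2ccccc2)c1` gives 19 nM. Compound 2 differs from compound 1 by methyl in place of hydrogen on a saturated chain carbon, four bonds along the chain from an aromatic nitrogen, a change that produced a 1.9-fold lower number from compound 1 to compound 2 (0.27 log units; within the scatter). Compound 3 differs from compound 1 by 1-phenylethyl in place of butyl on an aromatic nitrogen, which gave a 2.3-fold lower number from compound 1 to compound 3 (0.35 log units; beyond the scatter); the step of a 1.2-fold lower number from compound 2 to compound 3 (0.08 log units; within the scatter) is smaller still.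

Compound 4 `CCC(c1ccccc1)n1ccc2cc(/C(C)=C/C(=O)Nc3ccccc3OCCCC(=O)O)ccc21` is not yet measured. It differs from compound 3 by methyl in place of hydrogen on a saturated chain carbon, two bonds along the chain from an aromatic carbon and an aromatic nitrogen. This is the same kind of change as that from compound 1 to compound 2, but not the same: there the place was four bonds along the chain from an aromatic nitrogen, here it is two bonds along the chain from an aromatic carbon and an aromatic nitrogen. Because the earlier step of this kind, a 1.9-fold lower number from compound 1 to compound 2 (0.27 log units; within the scatter), stayed within the scatter, compound 4 is expected to show a similarly small step, a 1.3-fold lower number from compound 3 to compound 4 (0.10 log units; within the scatter). Compound 4 is therefore estimated at 15 nM in this assay, between 7 nM and 35 nM.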

Compound 4, half-maximal inhibitory concentration: 19 nM
Estimate against measurement, compound 4: 1.3-fold (0.10 log units) below; low and high end bracket the measured number.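

In this assay, adding the methyl gave no change at the digits printed from compound 3 to compound 4 (within the scatter), and the two steps of this kind can be set side by side: the same change on two cores in this assay, a 1.9-fold lower number (0.27 log units; within the scatter) from compound 1 to compound 2 and no change at the digits printed (within the scatter) from compound 3 to compound 4, 1.9-fold (0.27 log units) apart, within the scatter of two such steps. The steps therefore show no difference in how the change carries from one core to the other, but with one pair per core, different places of attachment and both steps within the scatter, they do not show that it has a real effect on either core. Placing 1-phenylpropyl on the aromatic nitrogen in place of a straight chain gives a 1.2-fold lower number from compound 2 to compound 4 (0.08 log units; within the scatter) and a 2.3-fold lower number from compound 1 to compound 4 (0.35 log units; beyond the scatter).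

Going by these compounds, it remains open how a hexyl chain or a 1-phenylbutyl group on that nitrogen would read. The compounds shown also leave open whether a longer branch would separate from compound 3 beyond the scatter.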